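The source may hold more compounds than are shown below. What is called first, only, known or untested is meant among the compounds shown, and "the series" means these compounds.

Values in a functional assay on A549 cells (Homo sapiens) for antiproliferative activity, read by CCK-8 assay, with a stated time of 72 h; a higher number here means a weaker inhibitor, a lower number a stronger inhibitor:
- compound 1 `Cc1cc(Nc2cc(N3CCN(C)CC3)nc(Nc3ccc(S(N)(=O)=O)cc3)n2)n[nH]1`: 16700 nM
- compound 2 `Cc1cc(Nc2cc(N3CCN(C)CC3)nc(Nc3ccc(Cl)cc3)n2)n[nH]1`: 631 nM
- compound 3 `Cc1cc(Nc2cc(N3CCN(C)CC3)nc(Nc3ccc(C#N)cc3)n2)n[nH]1`: 785 nM

On these numbers, the cyano analogue sits in the lower pair of the series. Replacing chloro with cyano gives a 1.2-fold higher number from compound 2 to compound 3 (0.09 log units; within the scatter), whereas the sulfamoyl exchanges give a 26-fold lower number from compound 1 to compound 2 (1.42 log units; beyond the scatter) and a 21-fold lower number from compound 1 to compound 3 (1.33 log units; beyond the scatter).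

Compound 4 `COc1ccc(Nc2nc(Nc3cc(C)[nH]n3)cc(N3CCN(C)CC3)n2)cc1` carries methoxy in place of cyano on an aromatic carbon, para to a large group (methoxy in place of cyano on an aromatic carbon). Among the compounds with values here, no measured step introduces methoxy, so the evidence is indirect. The large steps show that this site can matter, but both involve losing sulfamoyl. Within the data shown here, the only exchange without sulfamoyl stayed within the scatter, so no step beyond the scatter is expected in this assay, though the uncertainty is wide. The expected step is a 1.1-fold higher number from compound 3 to compound 4 (0.06 log units; within the scatter). Compound 4 is estimated at 900 nM, with an expected range of 300 nM to 3000 nM.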

Compound 4, half-maximal inhibitory concentration: 2650 nM
The estimate for compound 4 lay 2.9-fold (0.47 log units) below the measured number, within the range that was stated.
By their numbers in this assay, from the lowest: compounds 2 and 3 (each within the scatter of the next); then compound 4; then compound 1.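

In this assay, this position now separates groups other than sulfamoyl: methoxy gives a 3.4-fold higher number from compound 3 to compound 4 (0.53 log units; beyond the scatter) and a 4.2-fold higher number from compound 2 to compound 4 (0.62 log units; beyond the scatter), so the flat chloro-to-cyano exchange does not extend to every replacement at this aromatic carbon. Methoxy still improves on sulfamoyl, with a 6.3-fold lower number from compound 1 to compound 4 (0.80 log units; beyond the scatter), but compound 4 does not reach the values of compound 2 or compound 3. No supporting data on the compounds shown account for these differences.

From the compounds shown here alone, it remains open whether an amine or a carboxylic acid at this carbon would fall nearer to methoxy or to sulfamoyl. A fluoro or methyl group would show whether chloro and cyano are typical of small replacements here.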